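Single methyl on the bridging carbon of a phenyl ketone

The source may hold more compounds than are shown below. What is called first, only, known or untested is meant among the compounds shown, and "the series" means these compounds.

Measured compounds:
compound 1, `CC(C)(C(=O)c1ccccc1)c1cccnc1`, 3300 nM
compound 2, `CC(C)(Cc1ccccc1)c1cccnc1`, 660 nM
compound 3, `O=C(Cc1cccnc1)c1ccccc1`, 158000 nM

The three compounds were tested in a functional assay for inhibition of cytochrome P450 11B1, mitochondrial (Bos taurus); on this read-out lower numbers stand for stronger inhibition and higher numbers for weaker inhibition. Compound 3 stands at the top of these numbers: against compound 1, which gives 3300 nM, and compound 2, which gives 660 nM, compound 3 shows the highest value, 158000 nM, and both gaps lie beyond the scatter, so compound 3 is the weakest inhibitor of the three.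

Compound 4, `CC(C(=O)c1ccccc1)c1cccnc1`, has not been measured. It differs from compound 3 in one place: methyl in place of hydrogen on a saturated chain carbon bound to an aromatic carbon and a carbonyl carbon. Compound 1 carries two methyl groups on that same chain carbon and its value is far lower than that of compound 3, so a single methyl is expected to move the number in the same direction, by a sizeable step, though probably not the whole way. The step from compound 3 to compound 4 is expected to be a 7.9-fold lower number from compound 3 to compound 4 (0.90 log units; beyond the scatter). Compound 4 is therefore estimated at 20000 nM, within a range from 5000 nM to 80000 nM.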

Compound 4, half-maximal inhibitory concentration: 7720 nM
For compound 4 the middle estimate is 2.6-fold (0.41 log units) above the measured one; measured number inside the range.
By their numbers in this assay, from the lowest: compound 2; then compound 1; then compound 4; then compound 3.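

In this assay the single methyl in place of hydrogen on the saturated chain carbon gives a 20-fold lower number from compound 3 to compound 4 (1.31 log units; beyond the scatter) and so shows that one added carbon at this place already accounts for a large change. Removing one methyl from the pair gives only a 2.3-fold higher number from compound 1 to compound 4 (0.37 log units; beyond the scatter) and thus a modest step, so the second methyl still counts, but its step is much smaller than that of the first. Nothing at hand bears on why this methyl has so large an effect.

As far as these compounds go, whether an ethyl group, a longer chain or a hydroxyl group on this carbon would lower the number further, hold it or raise it remains open. Also open, from the compounds shown here alone, is whether a single methyl would act in the same way on the core of compound 2, which has no carbonyl.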